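Swapping a Chlorophenyl for a Pyridinyl in a Weak Series

The compounds below may be only part of what the source reports. "The series", "measured", "known", "first", "only" and "open" are said of these compounds alone.

Of the compounds shown here, three sharing an oxadiazole core have been tested in a functional assay on MDA-MB-231 cells (Homo sapiens) for antiproliferative activity, read by MTT assay, with a stated time of 24 h; a higher number here means a weaker inhibitor, a lower number a stronger inhibitor. Compound 1 `COc1cc(-c2noc(-c3ccncc3)n2)ccc1OCc1ccccc1` reaches only a limit of the assay, > 1000000 nM. Compound 3 `Fc1ccc(-c2nc(-c3ccccc3)no2)cc1` likewise reaches only a limit, > 1000000 nM. Within the data shown here, compound 2 `COc1ccc(-c2noc(-c3ccc(Cl)cc3)n2)cc1OC1CCCC1` is the one member with a measured number, giving 396000 nM in this assay, so among the values shown compound 2 alone stands inside the range the assay can report, while the other two sit at the limit of > 1000000 nM in this assay, at which 2 of the 3 values shown sit.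

Compound 4 `COc1ccc(-c2noc(-c3ccncc3)n2)cc1OC1CCCC1` has not yet been measured. Relative to compound 2 it carries pyridin-4-yl in place of 4-chlorophenyl on an aromatic carbon. Among the measured compounds shown here, no measured pair of compounds isolates this change, so the expectation rests only on the weak activity seen throughout. Compound 4 is expected to remain a weak inhibitor, with the step of a 2.0-fold higher number from compound 2 to compound 4 (0.31 log units; beyond the scatter) estimated as a modest loss, possibly beyond the scatter, since compound 1, which also bears pyridin-4-yl, gave > 1000000 nM. Compound 4 is therefore estimated at 800000 nM, within 300000 nM to 3000000 nM, and may well return only a limit.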

Compound 4, half-maximal inhibitory concentration: 240000 nM
The estimate for compound 4 lay 3.3-fold (0.52 log units) above the measured number; measured number below the stated range.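

In this assay, this position on the shared core accepts pyridin-4-yl in place of 4-chlorophenyl with no change that can be told from scatter: the step is a 1.7-fold lower number from compound 2 to compound 4 (0.22 log units; within the scatter). Among these compounds, this is the first pair differing in only one place, and it shows that swapping a carbon-only aromatic ring for one with a ring nitrogen leaves the activity weak. Pyridin-4-yl on this core also gives a real number rather than a limit, while the limit remains the only reading for the other compounds: the limit of > 1000000 nM in this assay, at which 2 of the 4 values shown sit.

A single exchange cannot show whether an amine or a carboxylic acid on this ring would move the number beyond the scatter. Among the compounds shown here, the effect of changes elsewhere on the core remains open, since this is the only step available.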